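Compound 3 at its limit: the pyridin-2-yl step

This account rests on a few compounds, and the source may have more. Where it says the series, first, only, none or still open, it means among the compounds named here.

Compound 1 `COc1ccc(C(=O)/C=C/c2ccc(N(C)C)cc2)c2c1C=CC(C)(C)O2`: 1870 nM
Compound 2 `COc1ccc(C(=O)/C=C/c2cccc([N+](=O)[O-])c2)c2c1C=CC(C)(C)O2`: 4260 nM
Compound 3 `COc1ccc(C(=O)/C=C/c2ccccc2)c2c1C=CC(C)(C)O2`: > 10000 nM

All three results come from a functional assay on HT-29 cells (Homo sapiens) for antiproliferative activity, read by MTT assay, with a stated time of 24 h; a lower number here means a stronger inhibitor, a higher number a weaker inhibitor. Compound 3 gives > 10000 nM, which is a limit of the assay and not a number. For the measured compounds named here, this is the only such result so far: the limit of > 10000 nM in this assay, at which 1 of the 3 values shown sits. Compounds 1 and 2 both return numbers.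

The next entry is compound 4 `COc1ccc(C(=O)/C=C/c2ccccn2)c2c1C=CC(C)(C)O2`, with pyridin-2-yl in place of phenyl on a double-bonded chain carbon bound to a double-bonded chain carbon.

Going by the values given here, no measured step makes this exchange. The nearest are an at least 5.3-fold higher number from compound 1 to compound 3 (0.72 log units; beyond the scatter) and an at least 2.3-fold higher number from compound 2 to compound 3 (0.37 log units; beyond the scatter), with hydrogen in place of dimethylamino and nitro on an aromatic carbon. Going by these compounds, both end at the limit, so their true sizes remain open. They show that compound 3 can be improved by a change on this aromatic ring, but they do not show what a ring nitrogen would do. In this assay, a shift to a lower number is therefore expected, no larger than those two steps and possibly none beyond the scatter. The expected step is an at least 1.4-fold lower number from compound 3 to compound 4 (0.15 log units; that floor lies within the scatter). For compound 4 the estimated value is 7000 nM, with an expected range of 2500 nM to 20000 nM.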

Compound 4, half-maximal inhibitory concentration: 2120 nM
Beside the measured number, compound 4's estimate is 3.3-fold (0.52 log units) above it; measured number outside the range, below it.
By their numbers in this assay, from the lowest: compounds 1, 4 and 2 (each within the scatter of the next, the first and the last beyond it). At a limit, above all of these: compound 3.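

In this assay, for the compounds shown here, pyridin-2-yl in place of phenyl on a double-bonded chain carbon bound to a double-bonded chain carbon gives an at least 4.7-fold lower number from compound 3 to compound 4 (0.67 log units; beyond the scatter), so exchanging a ring carbon for a ring nitrogen also moves the series off the limit, where the earlier compounds showed this only for dimethylamino and nitro on the phenyl ring. Compound 3 remains at a limit of the assay, so this step gives only a floor: the limit of > 10000 nM in this assay, at which 1 of the 4 values shown sits.

The two other new steps, a 2.0-fold lower number from compound 2 to compound 4 (0.30 log units; within the scatter) and a 1.1-fold higher number from compound 1 to compound 4 (0.05 log units; within the scatter), both lie within the scatter, so compound 4 cannot be separated from either compound 1 or compound 2, even though those two are separated from each other.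

The compounds shown leave open whether this gain depends on where the nitrogen sits in the ring, which pyridin-3-yl or pyridin-4-yl at the same place would test. They also leave open whether the ring nitrogen and a substituent combine, as a dimethylamino or an amine group on the pyridin-2-yl ring would show.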